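A few compounds are considered here, and "the series" means these few. Any claim that something is new, unique, unknown or untested is made for them only; others in the source may bear on it.

Compound 1 `O=C(c1ccc(C(F)(F)F)cc1)N(/N=N/c1ccc([N+](=O)[O-])cc1Cl)c1ccc([N+](=O)[O-])cc1Cl` gives 1060 nM in a functional assay on HeLa cells (Homo sapiens) for cytotoxicity, read by MTT assay, with a stated time of 72 h; a lower number here means a stronger inhibitor, a higher number a weaker inhibitor. Compound 2 `O=C(c1cccc(F)c1)N(/N=N/c1ccc([N+](=O)[O-])cc1Cl)c1ccc([N+](=O)[O-])cc1Cl` gives 2500 nM in this assay. The change between them is 3-fluorophenyl in place of 4-(trifluoromethyl)phenyl on a carbonyl carbon, and the step it made was a 2.4-fold higher number from compound 1 to compound 2 (0.37 log units; beyond the scatter), a modest weakening. Compound 3 `O=C(c1ccc(C(F)(F)F)cc1)N(/N=N/c1ccc([N+](=O)[O-])cc1C(F)(F)F)c1ccc([N+](=O)[O-])cc1C(F)(F)F` gives 690 nM in this assay; how its core differs from the core of compound 1 is not broken down here. Compound 4 `O=C(c1cccc(F)c1)N(/N=N/c1ccc([N+](=O)[O-])cc1C(F)(F)F)c1ccc([N+](=O)[O-])cc1C(F)(F)F` has not yet been measured. It differs from compound 3 by 3-fluorophenyl in place of 4-(trifluoromethyl)phenyl on a carbonyl carbon, which is the same change, at the same place, that turned compound 1 into compound 2. This change occurs only twice among these compounds. The expectation therefore rests on a single measured step, a 2.4-fold higher number from compound 1 to compound 2 (0.37 log units; beyond the scatter). The expected step is a 2.4-fold higher number from compound 3 to compound 4 (0.38 log units; beyond the scatter), of similar size. Compound 4 is therefore estimated at 1650 nM, with a likely range from 900 nM to 3200 nM.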

Compound 4, half-maximal inhibitory concentration: 880 nM
Compound 4: middle estimate off by 1.9-fold (0.27 log units), on the high side; measured number outside the range, below it.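

In this assay, 3-fluorophenyl in place of 4-(trifluoromethyl)phenyl on the carbonyl carbon gives a 1.3-fold higher number from compound 3 to compound 4 (0.11 log units; within the scatter), so on this core the change makes no clear difference. The step is smaller than the earlier one, but the gap between them is no larger than two such steps normally scatter: the same change on two cores in this assay, a 2.4-fold higher number (0.37 log units; beyond the scatter) from compound 1 to compound 2 and a 1.3-fold higher number (0.11 log units; within the scatter) from compound 3 to compound 4, 1.8-fold (0.27 log units) apart, within the scatter of two such steps. The change therefore behaves compatibly on both cores, but two pairs cannot show that its size is truly the same on both, or that it would hold on any other core.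

The compounds shown leave open what an amine or a longer carbon chain in place of these aromatic groups on the carbonyl carbon would give in this assay.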